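Working notes: the step from compound 2 to compound 3

The source may report more compounds than this note shows. Statements on the series, on what has been measured and on what is new or still open speak of the compounds shown alone.

In an ADME assay on the whole organism (Rattus norvegicus, strain Sprague-Dawley) for pharmacokinetics, using cassette dosing, at a dose of 0.5 mg/kg by the intravenous route (a lower number here means slower removal, a higher number faster removal of the compound), compound 1 (`O=C(Nc1ccc2[nH]c(=O)oc2c1)C(=O)N1CCN(c2ccc(F)c(F)c2)CC1`) gives 4 mL/min/kg and compound 2 (`C[C@@H]1CN(C(=O)C(=O)Nc2ccc3[nH]c(=O)oc3c2)CCN1c1ccc(Cl)cc1`) gives 15.6 mL/min/kg, the higher of the two numbers and beyond the scatter of compound 1. Compound 3 (`C[C@@H]1CN(C(=O)C(=O)Nc2ccc3[nH]c(=O)oc3c2)CCN1c1ccc(F)c(F)c1`) carries 3,4-difluorophenyl in place of the 4-chlorophenyl of compound 2, on an amine nitrogen in a ring (3,4-difluorophenyl in place of 4-chlorophenyl on an amine nitrogen in a ring). Compound 1 carries the same 3,4-difluorophenyl and gives 4 mL/min/kg, so a lower number is expected in this assay. The expected step, a 1.8-fold lower number from compound 2 to compound 3 (0.26 log units; within the scatter), is not clearly beyond the scatter. For compound 3 the estimate is 8.5 mL/min/kg, with an expected range of 4 mL/min/kg to 18 mL/min/kg.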

Compound 3, clearance: 15.9 mL/min/kg
Compound 3: middle estimate off by 1.9-fold (0.27 log units), on the low side, and the stated range covers the measured number.
By their numbers in this assay, from the lowest: compound 1; then compounds 2 and 3 (each within the scatter of the next).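

In this assay, 3,4-difluorophenyl in place of 4-chlorophenyl on the amine nitrogen in a ring shows no change (a 1.0-fold higher number from compound 2 to compound 3 (0.01 log units; within the scatter)), so with the methyl group present these two groups are not told apart at this position. Methyl in place of hydrogen on the saturated ring carbon, with 3,4-difluorophenyl held constant, gives the step beyond the scatter (a 4.0-fold higher number from compound 1 to compound 3 (0.60 log units; beyond the scatter)). Open, on these data alone, is whether an ethyl or hydroxymethyl group on that ring carbon would give the same number as methyl. Nothing at hand accounts for either step.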